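This account rests on a few compounds, and the source may have more. Where it says the series, first, only, none or still open, it means among the compounds named here.

Compound 2 `CCOC(=O)/C(=C/c1ccccc1)CN1C(=O)[C@@H](OC)[C@H]1c1ccc(F)cc1` sits among three compounds that share the same core and differ only in the aromatic ring attached to a saturated ring carbon. In a functional assay on MDA-MB-231 cells (Homo sapiens) for antiproliferative activity, read by MTT assay, with a stated time of 48 h (on this read-out lower numbers stand for stronger inhibition and higher numbers for weaker inhibition), compound 2 gives 14000 nM. Its two companions are compound 1 `COC(=O)/C(=C/c1ccccc1)CN1C(=O)[C@@H](OC)[C@H]1c1ccc(Cl)cc1`, which in this assay gives 15600 nM, and compound 3 `COC(=O)/C(=C/c1ccccc1)CN1C(=O)[C@@H](OC)[C@H]1c1ccccc1C(F)(F)F`, which gives 17600 nM. Of the three numbers, that of compound 2 is the lowest, yet its gaps to compound 1 and to compound 3 both lie within the usual scatter, so the three compounds cannot be told apart on this read-out.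

The next compound, compound 4 `CCOC(=O)/C(=C/c1ccccc1)CN1C(=O)[C@@H](OC)[C@H]1c1ccccc1Br`, is reached from compound 2 by one change: 2-bromophenyl in place of 4-fluorophenyl on a saturated ring carbon. For the measured compounds named here, the only measured step of the same kind, an exchange of the aromatic ring on that saturated ring carbon, is a 1.1-fold higher number from compound 1 to compound 3 (0.05 log units; within the scatter), which stayed within the scatter. On that basis the step from compound 2 to compound 4 is expected to be a 1.1-fold higher number from compound 2 to compound 4 (0.03 log units; within the scatter), not beyond the scatter. Compound 4 is therefore estimated at 15000 nM in this assay, within a range of 7000 nM to 32000 nM.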

Compound 4, half-maximal inhibitory concentration: 6860 nM
For compound 4 the middle estimate is 2.2-fold (0.34 log units) above the measured one, outside the stated range (below it).
By their numbers in this assay, from the lowest: compound 4; then compounds 2, 1 and 3 (each within the scatter of the next).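

The aromatic ring on this saturated ring carbon can move the result after all: 2-bromophenyl in place of 4-fluorophenyl gives a 2.0-fold lower number from compound 2 to compound 4 (0.31 log units; beyond the scatter), and a lower number here means stronger inhibition. For the compounds shown here, the earlier exchange, a 1.1-fold higher number from compound 1 to compound 3 (0.05 log units; within the scatter), stayed within the scatter, so this is the first sign that the position responds to the ring it carries, although the step is modest and rests on a single pair. Nothing available accounts for the lower number of the bromine-bearing ring.

From the compounds shown here alone, this step changes the halogen and its place on the ring together, so it remains open which of the two matters. Also open, going by these compounds, is what an aromatic ring carrying an amine or a carboxylic acid would give on this carbon.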